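Removing the Aromatic Fluorine From a Sulfonamide Series

A few compounds are considered here, and "the series" means these few. Any claim that something is new, unique, unknown or untested is made for them only; others in the source may bear on it.

Measured compounds:
compound 1, `O=C(c1ccc(OCCCN2CC[C@H](NS(=O)(=O)c3ccc(Br)cc3)C2)cc1)C1CC1`: 290 nM
compound 2, `CC(=O)c1ccc(OCCCN2CC[C@H](NC(=O)[C@@H](N)CO)C2)cc1`: 22000 nM
compound 3, `O=C(c1ccc(OCCCN2CC[C@H](NS(=O)(=O)c3ccc(F)cc3)C2)cc1)C1CC1`: 500 nM

In an assay on isolated protein for binding affinity to histamine H2 receptor (Homo sapiens) (a higher number here means a weaker inhibitor, a lower number a stronger inhibitor), compound 3 stands second highest of the three numbers. Its nearest neighbour is compound 1, reached by the step of a 1.7-fold higher number from compound 1 to compound 3 (0.24 log units; within the scatter), a change that stays within the scatter. For the measured compounds named here, compound 2 lies far away: compound 2 gives 22000 nM, a gap well beyond the scatter, but compound 2 differs from compound 3 in more than one place and no single step links them.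

Compound 4 is `O=C(c1ccc(OCCCN2CC[C@H](NS(=O)(=O)c3ccccc3)C2)cc1)C1CC1`. It differs from compound 3 by hydrogen in place of fluoro on an aromatic carbon. Going by the values given here, the only measured step that bears on this change is the one from compound 1 to compound 3, where one halogen replaced another and the number barely moved. Among the compounds with values here, no measured pair shows the halogen taken away altogether. On that basis the step of a 1.3-fold higher number from compound 3 to compound 4 (0.11 log units; within the scatter) is expected to be small, with at most a slight rise in the number. Compound 4 is therefore estimated at 650 nM, within a range from 250 nM to 1700 nM.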

Compound 4, inhibition constant: 1200 nM
The estimate for compound 4 lay 1.8-fold (0.27 log units) below the measured number, and the stated range covers the measured number.
By their numbers in this assay, from the lowest: compounds 1 and 3 (each within the scatter of the next); then compound 4; then compound 2.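

In this assay, removing the halogen outright does what exchanging one halogen for another did not: a 2.4-fold higher number from compound 3 to compound 4 (0.38 log units; beyond the scatter) and a 4.1-fold higher number from compound 1 to compound 4 (0.62 log units; beyond the scatter) both lie beyond the scatter, whereas a 1.7-fold higher number from compound 1 to compound 3 (0.24 log units; within the scatter) stays within it. Across these three compounds, then, what counts at this place, para to a large group, is whether a halogen is present at all more than which of the two it is, since the phenyl of compound 4 gives a higher number than either halogen-bearing compound. Nothing measured here speaks to the reason for this rise.

As far as these compounds go, whether a methyl, a methoxy group or an amine at the same place would give numbers like those of the halogens remains open. So does whether chlorine would fall with bromo and fluoro.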